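This account rests on a few compounds, and the source may have more. Where it says the series, first, only, none or still open, it means among the compounds named here.

Working notes on a small hydantoin-type series read out in a functional assay on MOLT-4 cells (Homo sapiens) for inhibition; a higher number here means a weaker inhibitor, a lower number a stronger inhibitor.

Compound 1 `CCC(C)C1NC(=O)N(C2CCCCC2)C1=O` carries a sec-butyl group on the ring and a cyclohexyl group on the ring nitrogen. In this assay compound 1 gives only a limit, > 200000 nM. Compound 2 `CCC(C)C1NC(=O)N(C2CCCC2)C1=O` keeps the sec-butyl group but carries a cyclopentyl group instead. In this assay compound 2 likewise gives only a limit, > 200000 nM. Compound 3 `CC(C)C1NC(=O)N(C2CCCC2)C1=O` pairs the cyclopentyl group with an isopropyl group. In this assay compound 3 again gives only a limit, > 200000 nM. The difference between the cores of compound 1 and compound 2 is not broken down here.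

Within the cyclopentyl pair the change hydrogen in place of methyl on a saturated chain carbon, two bonds along the chain from a saturated ring carbon produces a step that the two limits leave unreadable from compound 2 to compound 3; all three values shown sit at the limit of > 200000 nM in this assay, at which 3 of the 3 values shown sit, so the series so far contains no readable step at all.

Compound 4 `CC(C)C1NC(=O)N(C2CCCCC2)C1=O` has not yet been measured in this assay. It differs from compound 1 by hydrogen in place of methyl on a saturated chain carbon, two bonds along the chain from a saturated ring carbon, which is the same change already made from compound 2 to compound 3, at the same place. Since the cyclopentyl analogues gave only a limit, and compound 1 itself gives > 200000 nM, the expectation for compound 4 is a further limit rather than a number; the expected step that the limit leaves unreadable from compound 1 to compound 4 is therefore not one that can be read. Compound 4 is estimated at 300000 nM, within an expected range of 150000 nM to 1000000 nM.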

Compound 4, half-maximal inhibitory concentration: > 200000 nM
Compound 4: only a limit was reported; the forecaster's own chance of this, stated with the estimate: 95%; the middle value is on the limit's open side.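

In this assay compound 4 gives only a limit, > 200000 nM. Compound 1 also gives only a limit, so no new step can be read from compound 1 to compound 4, and the series stays without a readable value: the limit of > 200000 nM in this assay, at which 4 of the 4 values shown sit. The compounds shown leave open what size the change from sec-butyl to isopropyl has, and whether any group on the shared core gives a measurable value in this assay.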